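The source may report more compounds than this note shows. Statements on the series, on what has been measured and on what is new or still open speak of the compounds shown alone.

The set contains two measured compounds and one that remains to be measured. Compound 1 `O=C(O)CCC(=O)N(C1CC1)[C@H]1c2ccccc2N(C(=O)c2ccc(OC(F)(F)F)cc2)[C@H]2CC[C@H]21` gives 3.9 nM in a functional assay for antagonist activity at prostaglandin D2 receptor 2 (Homo sapiens), read by flow cytometry, with stated times of 10 min and 4 min; a lower number here means a stronger inhibitor, a higher number a weaker inhibitor. Compound 2 `O=C(O)COC(=O)N(C1CC1)[C@H]1c2ccccc2N(C(=O)c2cccc(F)c2)[C@H]2CC[C@H]21` gives 13 nM in the same assay, and it stands with the higher of the two numbers, compound 1 lying lower by a gap that is beyond the scatter. Compound 1 and compound 2 differ from each other in more than one place, so the gap between them cannot be assigned to any single change on its own.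

Compound 3 `O=C(O)CCC(=O)N(C1CC1)[C@H]1c2ccccc2N(C(=O)c2cccc(F)c2)[C@H]2CC[C@H]21` is obtained from compound 2 by a single change: 2-carboxyethyl in place of carboxymethoxy on a carbonyl carbon. This brings the acid-bearing chain of compound 3 into the same form as that found in compound 1, while everything else in compound 3 stays as in compound 2. Within the data shown here, no measured pair in this set shows this change alone.

From compound 2 to compound 3 the expected step is a 1.6-fold lower number from compound 2 to compound 3 (0.21 log units; within the scatter), leaning toward a somewhat lower number, with only the lower value of compound 1 as loose support. Compound 3 is therefore estimated at 8 nM, within a range of 3 nM to 25 nM.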

Compound 3, half-maximal inhibitory concentration: 14 nM
Compound 3: the middle estimate sits 1.8-fold (0.24 log units) below what was measured, and the stated range covers the measured number.
By their numbers in this assay, from the lowest: compound 1; then compounds 2 and 3 (each within the scatter of the next).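

In this assay, 2-carboxyethyl in place of carboxymethoxy on a carbonyl carbon whose other neighbour is the amide-type nitrogen gives a 1.1-fold higher number from compound 2 to compound 3 (0.03 log units; within the scatter), so with the 3-fluorophenyl group held fixed, this step does not tell the two chains apart. With the 2-carboxyethyl chain held fixed, 3-fluorophenyl in place of 4-(trifluoromethoxy)phenyl gives a 3.6-fold higher number from compound 1 to compound 3 (0.56 log units; beyond the scatter) and lies beyond the scatter, so of the two single changes now readable, only the change of aryl group shows a difference. Nothing measured here accounts for either step.

The compounds shown leave open whether carboxymethoxy and 2-carboxyethyl would also stay within the scatter of each other with 4-(trifluoromethoxy)phenyl in place, since carboxymethoxy appears here only with 3-fluorophenyl. They also leave open how the number would respond to a longer chain such as 3-carboxypropyl at this carbonyl carbon, or to an amine in place of the carboxylic acid.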